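The compounds below may be only part of what the source reports. "The series", "measured", "known", "first", "only" and "open" are said of these compounds alone.

Measured compounds:

Compound 1, `COCOc1cc(/C=C/C(=O)OCC(=O)Nc2ccc(OC)cc2)ccc1OCc1ccccc1`: in a functional assay on HeLa cells (Homo sapiens) for cytotoxicity, read by MTT assay, with a stated time of 72 h (on this read-out higher numbers stand for weaker inhibition and lower numbers for stronger inhibition), compound 1 gives 155000 nM.
Compound 2, `COCOc1cc(/C=C/C(=O)OCC(=O)Nc2ccc(Cl)cc2)ccc1OCc1ccccc1`: for compound 2 this assay reports only a limit, > 200000 nM, as in the limit of > 200000 nM in this assay, at which 1 of the 3 values shown sits.
Compound 3, `O=C(COC(=O)/C=C/c1ccc(O)c(O)c1)Nc1ccc(Cl)cc1`: in this assay compound 3 gives 195000 nM.

Compound 1 and compound 2 share one core and differ in a single place: methoxy in place of chloro on an aromatic carbon. Across that change the number moves by an at least 1.2-fold lower number from compound 2 to compound 1 (0.11 log units; that floor lies within the scatter), a step that sits within the scatter of repeated measurements and so tells little about direction. Compound 3 carries a different core; how the core of compound 3 differs from the core of compound 2 is not broken down here. The values of compound 3 and compound 1 lie within the scatter of one another.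

Compound 4, `COc1ccc(NC(=O)COC(=O)/C=C/c2ccc(O)c(O)c2)cc1`, has not yet been measured in this assay. It is made from compound 3 by methoxy in place of chloro on an aromatic carbon, the same change, at the same kind of place, that leads from compound 2 to compound 1. Since that change gave only an at least 1.2-fold lower number from compound 2 to compound 1 (0.11 log units; that floor lies within the scatter), the step from compound 3 to compound 4 is expected to be similarly small, estimated as a 1.3-fold lower number from compound 3 to compound 4 (0.11 log units; within the scatter). On this basis compound 4 is expected to give about 150000 nM in this assay, estimated to lie between 80000 nM and 300000 nM.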

Compound 4, half-maximal inhibitory concentration: > 200000 nM
Compound 4: only a limit was reported; the forecaster's own chance of this, stated with the estimate: 25%; middle value at least 1.3-fold (0.12 log units) away from the limit.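

Compound 4 gives only a limit in this assay, > 200000 nM. The step from chloro to methoxy on this second core can therefore be read only as a floor, an at least 1.0-fold higher number from compound 3 to compound 4 (0.01 log units; that floor lies within the scatter), and set beside the step on the first core it stands as follows: the same change on two cores in this assay, an at least 1.2-fold lower number (0.11 log units; that floor lies within the scatter) from compound 2 to compound 1 and an at least 1.0-fold higher number (0.01 log units; that floor lies within the scatter) from compound 3 to compound 4; the limit leaves it open whether they differ. Neither floor lies beyond the scatter, so the pair does not show that the change carries over from one core to the other with the same size or direction, nor does it show that the change is without effect on either core, and the reach of the comparison ends at the limit of the read-out: the limit of > 200000 nM in this assay, at which 2 of the 4 values shown sit.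

Left open is whether an amine or a carboxylic acid in place of the chloro or methoxy on the aromatic ring would give a value clear of that limit in this assay, so that a step could be read in full. Also open, as far as these compounds go, is whether a longer chain in place of the short link joining the ester and the amide would move the numbers on either core.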